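Adding Chloro to Compound 3

The source may hold more compounds than are shown below. What is called first, only, known or untested is meant among the compounds shown, and "the series" means these compounds.

In a functional assay on SW480 cells (Homo sapiens) for antiproliferative activity, read by MTT assay, with a stated time of 48 h (on this read-out lower numbers stand for stronger inhibition and higher numbers for weaker inhibition), compound 3 `CCCCCCCCCC(CCO)n1cnc2c(N)ncnc21` gives 6030 nM, the lower of the two exact numbers. Compound 2 `CCCCCCCCCC(CCO)n1cnc2c(Cl)nc(Cl)nc21` gives 36300 nM. The gap between these two compounds lies clearly beyond the usual scatter. Compound 1 `CCCCCC(CCO)n1cnc2c(N)nc(Cl)nc21` reads > 50000 nM, which is a limit of the assay and not a number. Compound 4 `CCCCCCCCCC(CCO)n1cnc2c(N)nc(Cl)nc21` has chloro in place of hydrogen on an aromatic carbon of compound 3, between two ring nitrogen atoms: chloro in place of hydrogen on an aromatic carbon. For the measured compounds named here, no measured pair isolates this swap, so the guide is loose, but compound 2, which also carries chloro there, shows 36300 nM. An estimated 2.3-fold higher number from compound 3 to compound 4 (0.37 log units; beyond the scatter) would be a modest rise, meaning weaker inhibition. Compound 4 is expected at 14000 nM, with an estimated range of 5000 nM to 40000 nM.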

Compound 4, half-maximal inhibitory concentration: 12200 nM
Estimate against measurement, compound 4: 1.1-fold (0.06 log units) above; low and high end bracket the measured number.
By their numbers in this assay, from the lowest: compound 3; then compound 4; then compound 2. At a limit, above all of these: compound 1.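

In this assay chloro in place of hydrogen on this aromatic carbon, between two ring nitrogen atoms, now has a measured price of its own: the swap brings a 2.0-fold higher number from compound 3 to compound 4 (0.31 log units; beyond the scatter) and so weakens inhibition only modestly. With that chloro kept, amino in place of chloro on an aromatic carbon brings a 3.0-fold lower number from compound 2 to compound 4 (0.47 log units; beyond the scatter) and so goes with stronger inhibition. Butyl in place of hydrogen on a saturated chain carbon brings an at least 4.0-fold lower number from compound 1 to compound 4 (0.61 log units; beyond the scatter) and this step starts from a limit for compound 1: the limit of > 50000 nM in this assay, at which 1 of the 4 values shown sits.

On these data alone, whether fluoro or methoxy on this carbon would outdo hydrogen or chloro stays open. So does whether a chain longer than that of compound 4 would lower the number further.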